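This account rests on a few compounds, and the source may have more. Where it says the series, first, only, none or still open, it means among the compounds named here.

The measured compounds were:
compound 1, `O=C(/C=C/C1=Cc2ccccc2OC1)c1ccccc1Cl`, 52.3%
compound 2, `O=C(/C=C/C1=Cc2ccccc2OC1)c1ccc(Br)cc1`, 66%

For the measured compounds named here, in a functional assay on the whole organism for inhibition, with Mus musculus as the target, with a stated time of 1 h, at a dose of 30 mg/kg by the intraperitoneal route (a lower number here means less inhibition, a higher number more inhibition at the dose given (going by the name of the read-out)), compound 2 gives 66%, the higher of the two numbers so far; its nearest neighbour, compound 1, gives 52.3%. Going by the values given here, the single step between measured compounds, a number 13.7 percentage points higher from compound 1 to compound 2 (beyond the scatter), came from putting 4-bromophenyl in place of 2-chlorophenyl on a carbonyl carbon.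

Compound 3, `Cc1ccc(C(=O)/C=C/C2=Cc3ccccc3OC2)cc1`, is not yet measured. It differs from compound 2 in one place: methyl in place of bromo on an aromatic carbon. Among the compounds with values here, no measured step changes this position while the rest is held fixed, so the step from compound 1 to compound 2 bears on it only loosely: it shows that altering the group attached to the carbonyl carbon can shift the read-out by a modest amount, and it places compound 2 at the upper end of the two numbers. Within the data shown here, with no step that exchanges bromo for methyl anywhere, the expectation for compound 3 is a number close to that of compound 2, with a number 6 percentage points lower from compound 2 to compound 3 (within the scatter) expected as a step within the scatter in either direction. The estimate for compound 3 in this assay is 60%, expected to lie between 45% and 75%.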

Compound 3, a percentage reported as inhibition, in the whole organism at one dose (the size of the read-out at that dose, not a potency): 53.1%
Beside the measured number, compound 3's estimate is 6.9 percentage points above it; the measured number falls inside the stated range.
By their numbers in this assay, from the lowest: compounds 1 and 3 (each within the scatter of the next); then compound 2.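

In this assay, for the compounds shown here, the exchange of bromo for methyl on an aromatic carbon para to a large group is the first change measured at this position with the rest held fixed, and the read-out responds to it, giving a number 12.9 percentage points lower from compound 2 to compound 3 (beyond the scatter) as the step. The second step, a number 0.8 percentage points higher from compound 1 to compound 3 (within the scatter), shows that the 4-methylphenyl and 2-chlorophenyl groups cannot be told apart here, so among these three compounds only the 4-bromophenyl group of compound 2 stands apart from the others. Nothing at hand bears on why bromo and methyl part in this way.

On these data alone, whether the higher number of compound 2 belongs to bromo alone remains open, since a chloro or fluoro group at the same place, or a methoxy group, an amine or a carboxylic acid there, would be needed to show how far the read-out follows the group. Compound 1 and compound 2 also differ in both the halogen and where it sits, so the share of each in their step cannot be separated from these compounds.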